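This account rests on a few compounds, and the source may have more. Where it says the series, first, only, none or still open, it means among the compounds named here.

Two compounds share one core. Compound 1 `c1ccc(-c2cn3ccnc3c(-c3ccc4ncn(C5CCCCC5)c4c3)n2)cc1` carries a plain phenyl ring, and in a functional assay on IGROV-1 cells (Homo sapiens) for inhibition, read by sulforhodamine B assay, with a stated time of 48 h, tested at 10 uM (on this read-out higher numbers stand for more inhibition at the one concentration tested (going by the name of the read-out) and lower numbers for less inhibition), compound 1 gives 12%. Compound 2 `O=Cc1ccc(-c2cn3ccnc3c(-c3ccc4ncn(C5CCCCC5)c4c3)n2)cc1` bears a formyl group on that ring, and in this assay compound 2 gives 21.3%; the change amounts to a number 9.3 percentage points higher from compound 1 to compound 2 (within the scatter). Of the two numbers, that of compound 2 is the larger on paper, yet its gap to compound 1 lies within the usual scatter, so the two cannot be told apart. Compound 3 `CC(=O)c1ccc(-c2cn3ccnc3c(-c3ccc4ncn(C5CCCCC5)c4c3)n2)cc1` differs from compound 2 by methyl in place of hydrogen on a carbonyl carbon. Going by the values given here, only one measured step bears on this, and it showed that adding a group on this ring shifted the number no further than the scatter. A step of a number 0.7 percentage points higher from compound 2 to compound 3 (within the scatter) is therefore expected, nothing beyond the scatter. Compound 3 is estimated at 22%, with a range from 8% to 38%.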

Compound 3, a percentage reported as inhibition, at one concentration (the size of the read-out at that concentration, not a potency): 19.1%
Compound 3: the middle estimate sits 2.9 percentage points above what was measured, and the stated range covers the measured number.
By their numbers in this assay, from the lowest: compounds 1, 3 and 2 (each within the scatter of the next).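

In this assay, replacing formyl with acetyl gives a number 2.2 percentage points lower from compound 2 to compound 3 (within the scatter), so methyl in place of hydrogen on the carbonyl carbon produces no change that can be told apart. Set against the plain phenyl ring, acetyl in place of hydrogen on the aromatic carbon gives a number 7.1 percentage points higher from compound 1 to compound 3 (within the scatter), so there are now two carbonyl-bearing groups on this ring, and neither can be separated from compound 1. Nothing available explains these numbers.

As far as these compounds go, it remains open whether a different group at this place, such as an amine, a carboxylic acid or a longer chain, would move the number beyond the scatter. From the compounds shown here alone, a reading at one concentration also gives no potency, so any differences at other concentrations remain unknown.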